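A few compounds are considered here, and "the series" means these few. Any claim that something is new, unique, unknown or untested is made for them only; others in the source may bear on it.

Measured so far:
Compound 1, `CCc1ccc(NC(=O)N[C@H](C)c2ccccc2)cc1`: 95% in an ADME assay on the whole organism with Oryza sativa as the target, tested at 0.1 uM; a higher number here means a weaker effect of the compound at the concentration tested, a lower number a stronger effect
Compound 2, `CCc1ccc(NC(=O)N[C@@H](C)c2ccccc2)cc1`: 99% in this assay

Compound 2 stands highest of the two numbers shown in this assay, with compound 1 nearest at a number 4 percentage points higher from compound 1 to compound 2 (within the scatter). Among the measured compounds shown here, both compounds have the same atoms and bonds and differ only in the configuration as drawn, which is the one point of evidence for that step (the fact that compounds 1 and 2 differ only in the configuration as drawn); the step itself lies within the scatter, so the two values show no difference that can be relied on.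

Compound 3, `CC(C)c1ccc(NC(=O)N[C@@H](C)c2ccccc2)cc1`, has not yet been measured in this assay. It differs from compound 2 by methyl in place of hydrogen on a saturated chain carbon bound to an aromatic carbon and a saturated chain carbon. For the measured compounds named here, no measured step covers a change of this kind: the one step available, a number 4 percentage points higher from compound 1 to compound 2 (within the scatter), concerns configuration only and says nothing about a methyl in place of hydrogen. Since the two values at hand sit close together and nothing points to a shift, no step beyond the scatter is expected for compound 3, whose value is estimated to differ from compound 2 by a number 3 percentage points lower from compound 2 to compound 3 (within the scatter). Compound 3 is therefore expected to give about 96%, between 85% and 100%.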

Compound 3, a percentage reported as activity, at one concentration (the size of the read-out at that concentration, not a potency): 98%
Compound 3: middle estimate off by 2 percentage points, on the low side, and the stated range covers the measured number.
By their numbers in this assay, from the lowest: compounds 1, 3 and 2 (each within the scatter of the next).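

The change from ethyl to isopropyl, which puts methyl in place of hydrogen on a saturated chain carbon bound to an aromatic carbon and a saturated chain carbon, gives a number 1 percentage points lower from compound 2 to compound 3 (within the scatter). The earlier pair shared the ethyl group and so said nothing about this position, whereas this step shows that, in this assay, one added methyl here brings no difference that can be relied on, and the compound stays in the same range of numbers as the ethyl compound with the same drawn configuration. Nothing measured on these compounds explains why this step stays so small.

Still open, going by these compounds, is whether a longer chain such as butyl, a ring such as cyclohexyl, or a different kind of group such as an amine or a carboxylic acid at this place would move the number in this assay beyond the scatter. The opposite drawn configuration combined with isopropyl is a further open case, as is the question of whether configuration matters at all once the ethyl group has given way to isopropyl.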